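This account rests on a few compounds, and the source may have more. Where it says the series, first, only, none or still open, it means among the compounds named here.

The measured compounds, with their values in an ADME assay on HEK293 cells (Homo sapiens) for cytotoxicity, read by MTT assay, with a stated time of 24 h; on this read-out higher numbers stand for weaker inhibition and lower numbers for stronger inhibition:

Compound 1, `O=C1O/C(=C\Cn2cc(Cc3ccccc3)nn2)C(OCc2ccccc2)=C1OCc1ccccc1`, gives 70000 nM.
Compound 3, `COC1=C(OC)C(O)(CCn2cc(-c3ccc(C(C)(C)C)cc3)nn2)NC1=O`, gives 62000 nM.
Compound 2, `O=C1NC(O)(CCn2cc(-c3ccccc3)nn2)C(OCc2ccccc2)=C1OCc1ccccc1`, gives > 100000 nM, which is a limit of the assay and not a number.

Compound 2 therefore stands at the edge of what this assay reports: its entry is the limit of the limit of > 100000 nM in this assay, at which 1 of the 3 values shown sits, and all that the data say is that its value lies at that limit. Among the compounds with values here, compound 1 and compound 3 each give a number, and neither of them differs from compound 2 by a single change, so no step between measured compounds is available to guide the next prediction.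

Compound 4, `Cc1ccc(-c2cn(CCC3(O)NC(=O)C(OCc4ccccc4)=C3OCc3ccccc3)nn2)cc1`, is made from compound 2 by methyl in place of hydrogen on an aromatic carbon, para to a large group. Within the data shown here, with no measured pair that isolates this change, no step size can be read from the data, and the expectation is for no step beyond the usual scatter of this assay. Compound 4 is thus expected to sit near where compound 2 sits, with a real chance that it too returns only a limit. The estimate for compound 4 in this assay is 95000 nM, with a range from 45000 nM to 200000 nM, corresponding to an expected step of an at least 1.0-fold lower number from compound 2 to compound 4 (0.02 log units; that floor lies within the scatter).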

Compound 4, half-maximal inhibitory concentration: 45000 nM
For compound 4 the middle estimate is 2.1-fold (0.32 log units) above the measured one; low and high end bracket the measured number.
By their numbers in this assay, from the lowest: compounds 4, 3 and 1 (each within the scatter of the next). At a limit, above all of these: compound 2.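

In this assay the change from phenyl to 4-methylphenyl, with methyl in place of hydrogen on an aromatic carbon, para to a large group, gives the only step that can be read among these compounds (an at least 2.2-fold lower number from compound 2 to compound 4 (0.34 log units; beyond the scatter)), and it shows that this single added carbon is enough to move the number beyond the scatter. Compound 2 gives > 100000 nM as its entry, which is a limit of the assay and not a number. The true size of the step therefore stays unknown, and only its lower bound can be stated, because one end of the pair stands at a limit: the limit of > 100000 nM in this assay, at which 1 of the 4 values shown sits.

The compounds shown leave open whether another group at the same place on the aromatic ring, such as a chlorine atom, a methoxy group, an amine or a carboxylic acid, would move the number in the same direction or by a similar amount. They also leave open whether methyl in place of hydrogen would give a comparable step on the core of compound 1 or in the setting of compound 3.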